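Dithiocarbamate amine variation on the shared core

A few compounds are considered here, and "the series" means these few. Any claim that something is new, unique, unknown or untested is made for them only; others in the source may bear on it.

Of the compounds shown here, three have been measured so far in a functional assay on LM7 cells (Homo sapiens) for antiproliferative activity, read by MTT assay, with a stated time of 72 h; a lower number here means a stronger inhibitor, a higher number a weaker inhibitor. Compound 1 `O=c1c(CSC(=S)N2CCCCC2)coc2cc(Cl)ccc12` gives 850 nM, compound 3 `O=c1c(CSC(=S)N2CCOCC2)coc2cc(Cl)ccc12` gives 6200 nM, and compound 2 `CCN(CC)C(=S)SCc1cc(=O)c2ccc(Cl)cc2o1` gives 8800 nM. On these numbers compound 2 stands highest of the three; its gap to compound 3 is within the scatter, its gap to compound 1 is beyond it. Within the data shown here, the single measured step, a 7.3-fold higher number from compound 1 to compound 3 (0.86 log units; beyond the scatter), is the only one that touches the amine on the thiocarbonyl carbon.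

Compound 4 `O=c1cc(CSC(=S)N2CCOCC2)oc2cc(Cl)ccc12` differs from compound 2 as follows: morpholin-4-yl in place of diethylamino on a thiocarbonyl carbon. Among the measured compounds shown here, no measured pair swaps diethylamino against anything, so the step bears on it only loosely: morpholin-4-yl gave the higher number against piperidin-1-yl, but compound 2 and compound 3 sit within the scatter of each other, which suggests diethylamino and morpholin-4-yl may behave alike. The expectation is therefore a step of about a 1.0-fold higher number from compound 2 to compound 4 (0.01 log units; within the scatter) in this assay, with no clear direction beyond the scatter. Compound 4 is estimated at 9000 nM, ranging from 4000 nM to 25000 nM.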

Compound 4, half-maximal inhibitory concentration: > 25000 nM
Compound 4 gave a limit, no number (the forecaster's own chance of this, stated with the estimate: 10%); at least 2.7-fold (0.44 log units) between middle value and limit.
By their numbers in this assay, from the lowest: compound 1; then compounds 3 and 2 (each within the scatter of the next). At a limit, above all of these: compound 4.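

In this assay, morpholin-4-yl in place of diethylamino on a thiocarbonyl carbon gives an at least 2.8-fold higher number from compound 2 to compound 4 (0.45 log units; beyond the scatter), so the closeness of compound 2 and compound 3 did not carry over to these two amines on the core of compound 2. Compound 4 stands at a limit and not at a number, which leaves this step a lower bound with no measured size: the limit of > 25000 nM in this assay, at which 1 of the 4 values shown sits. Together with a 7.3-fold higher number from compound 1 to compound 3 (0.86 log units; beyond the scatter), morpholin-4-yl now gives the higher number in both steps where it enters, and no compound shown goes against this.

Open, on these data alone, is how piperidin-1-yl would read on the core of compound 2, and whether the morpholin-4-yl step has a similar size on both cores. Also open, as far as these compounds go, is where a piperazine or a pyrrolidine on the thiocarbonyl carbon would fall on either core.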